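Chain substituent variation at the saturated chain carbon

The compounds below may be only part of what the source reports. "The series", "measured", "known", "first", "only" and "open" are said of these compounds alone.

Measured compounds in a functional assay on CHO cells for inhibition of transient receptor potential cation channel subfamily V member 1 (Homo sapiens); a higher number here means a weaker inhibitor, a lower number a stronger inhibitor:
compound 1 `CC(C)(C)c1ccc(/C(=C/C(=O)Nc2ccc3c(c2)OCCO3)c2ccncc2)cc1` gives 44 nM
compound 2 `CC(C)C/C(=C\C(=O)Nc1ccc2c(c1)OCCO2)c1ccc(C(C)(C)C)cc1` gives 16 nM

In this assay, for the measured compounds named here, compound 2 stands lowest of the two numbers, with compound 1 as its only neighbour. Going by the values given here, the single measured step, a 2.8-fold lower number from compound 1 to compound 2 (0.44 log units; beyond the scatter), concerns a different place on the chain. Compound 3 `CCOC(=O)CC/C(=C\C(=O)Nc1ccc2c(c1)OCCO2)c1ccc(C(C)(C)C)cc1` differs from compound 2 by (ethoxycarbonyl)methyl in place of isopropyl on a saturated chain carbon bound to a double-bonded chain carbon. Among the compounds with values here, no measured step touches this position, so the step size has no direct precedent; the one step shows only that changes on this chain can move the number modestly. A small shift, if any, is expected. The estimate for compound 3 is 30 nM, expected between 10 nM and 90 nM, corresponding to an expected step of a 1.9-fold higher number from compound 2 to compound 3 (0.27 log units; within the scatter).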

Compound 3, half-maximal inhibitory concentration: 36 nM
For compound 3 the middle estimate is 1.2-fold (0.08 log units) below the measured one, and the stated range covers the measured number.
By their numbers in this assay, from the lowest: compound 2; then compounds 3 and 1 (each within the scatter of the next).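

At the saturated chain carbon, (ethoxycarbonyl)methyl in place of isopropyl gives a 2.3-fold higher number from compound 2 to compound 3 (0.35 log units; beyond the scatter) in this assay and so keeps measurable inhibition, at a modest cost. Read on the double-bonded chain carbon, 2-(ethoxycarbonyl)ethyl in place of pyridin-4-yl gives a 1.2-fold lower number from compound 1 to compound 3 (0.09 log units; within the scatter) and does not separate the two groups. No measured evidence accounts for either step.

The compounds shown leave open whether the ethoxycarbonyl group itself matters at this position. A carboxylic acid or an amine at the end of this chain would test that.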